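Amide variation on a quinoline core in SK-BR-3 cells

The source may hold more compounds than are shown below. What is called first, only, known or untested is meant among the compounds shown, and "the series" means these compounds.

Measured compounds:
Compound 1, `CCN1CCN(c2cc(C)c3cc(NC(=O)c4ccc[nH]4)ccc3n2)CC1`: 13200 nM
Compound 2, `CCN1CCN(c2cc(C)c3cc(NC(=O)c4ccccc4)ccc3n2)CC1`: 18400 nM
Compound 3, `CCN1CCN(c2cc(C)c3cc(NC(=O)c4ccc5ccccc5n4)ccc3n2)CC1`: 3760 nM

The three compounds share one core and differ only in the aryl group on the amide carbonyl. In a functional assay on SK-BR-3 cells (Homo sapiens) for antiproliferative activity, read by MTT assay, with a stated time of 72 h (a lower number here means a stronger inhibitor, a higher number a weaker inhibitor), compound 1 stands second highest of the three numbers; its nearest neighbour is compound 2, at a 1.4-fold higher number from compound 1 to compound 2 (0.14 log units; within the scatter), and the furthest is compound 3, at a 3.5-fold lower number from compound 1 to compound 3 (0.55 log units; beyond the scatter). Between the other two, compound 3 lies at a 4.9-fold lower number from compound 2 to compound 3 (0.69 log units; beyond the scatter).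

Compound 4, `CCc1ccc(C(=O)Nc2ccc3nc(N4CCN(CC)CC4)cc(C)c3c2)cc1`, is not yet measured. It differs from compound 1 as follows: 4-ethylphenyl in place of 1H-pyrrol-2-yl on a carbonyl carbon. The step from compound 1 to compound 2 bears most directly on this change, since it also exchanges the five-membered heteroaromatic ring for a six-membered carbon-only ring, and that step stayed within the scatter. The quinolin-2-yl steps show that a larger aryl group can lower the number modestly, but 4-ethylphenyl is a single ring with a chain rather than a second fused ring, so compound 4 is expected at 12000 nM (range 4500 nM to 32000 nM), a step of a 1.1-fold lower number from compound 1 to compound 4 (0.04 log units; within the scatter) that is expected to lie within the scatter.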

Compound 4, half-maximal inhibitory concentration: 9850 nM
Beside the measured number, compound 4's estimate is 1.2-fold (0.09 log units) above it; the range from low to high includes it.
By their numbers in this assay, from the lowest: compound 3; then compounds 4, 1 and 2 (each within the scatter of the next).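

In this assay, ethyl in place of hydrogen on an aromatic carbon of the phenyl group leaves the number within the scatter (a 1.9-fold lower number from compound 2 to compound 4 (0.27 log units; within the scatter)), and the full exchange of 1H-pyrrol-2-yl for 4-ethylphenyl also stays within it (a 1.3-fold lower number from compound 1 to compound 4 (0.13 log units; within the scatter)), even though the entering group has no hydrogen-bond donor and the leaving group has one. The quinolin-2-yl group remains apart (a 2.6-fold higher number from compound 3 to compound 4 (0.42 log units; beyond the scatter)), so an ethyl chain on a single ring does not match compound 3, which now lies beyond the scatter of all three other compounds. No measurement is available that gives a reason for these differences.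

Going by these compounds, whether a longer chain, an amine or a carboxylic acid in place of the ethyl would move the number beyond the scatter remains open. Also open, on these data alone, is whether a fused ring other than quinolin-2-yl would lower the number as compound 3 does.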